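The source may hold more compounds than are shown below. What is called first, only, known or untested is meant among the compounds shown, and "the series" means these compounds.

Among the compounds with values here, in an ADME assay on microsomes from liver (Mus musculus) for metabolic stability, read by LC-MS, with a stated time of 30 min, tested at 1 uM (on this read-out higher numbers stand for a more stable compound and lower numbers for a less stable compound), compound 1 `O=C(NCc1ccc(S(=O)(=O)N2CCCCC2)cc1)c1cc2cnccc2o1` gives 4.6% and compound 2 `O=C(NCc1ccc(S(=O)(=O)N2CCCCC2)cc1)c1ccc2nc[nH]c2c1` gives 16%, the higher of the two numbers so far. Compound 3 `O=C(NCc1ccc(S(=O)(=O)N2CCCCC2)cc1)c1cc2cccnc2s1` differs from compound 2 as follows: a group of 9 heavy atoms (7 carbon, 1 nitrogen, 1 sulfur; one five-membered aromatic ring with 1 hetero atom, one six-membered aromatic ring with 1 hetero atom) in place of a group of 9 heavy atoms (7 carbon, 2 nitrogen; one five-membered aromatic ring with 2 hetero atoms, one six-membered aromatic ring of carbon only), on a carbonyl carbon. Within the data shown here, the only measured step bearing on this is a number 11.4 percentage points higher from compound 1 to compound 2 (beyond the scatter), a modest one. The entering group has the same ring description as the group of compound 1, so a small downward step, probably within the scatter, is expected. The expected step is a number 7 percentage points lower from compound 2 to compound 3 (within the scatter). For compound 3 the estimate is 9%, with an expected range of 2% to 25%.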

Compound 3, percent of the compound remaining: "below limit of detection" (no number reported)
The entry for compound 3 holds no number, so the estimate cannot be set against anything.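

Within the data shown here, compound 3 carries no number, so no step from compound 2 to compound 3 can be read. Nothing available bears on this result. As far as these compounds go, whether the group entering in compound 3 raises or lowers the percent of compound remaining relative to 1H-benzimidazol-6-yl stays open.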